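A few compounds are considered here, and "the series" means these few. Any claim that something is new, unique, unknown or untested is made for them only; others in the source may bear on it.

Working notes on the series built on the core of compound 1 `O=C(CC(CC(=O)NC1Cc2ccccc2C1)c1ccc(Cl)cc1)NCCN1CCCCC1`. In a functional assay on MGC-803 cells (Homo sapiens) for inhibition (on this read-out higher numbers stand for weaker inhibition and lower numbers for stronger inhibition), compound 1 gives 89100 nM. Among the measured compounds shown here, in the same read-out compound 3 `CCN(C(=O)CC(CC(=O)NCCN1CCCCC1)c1ccc(Cl)cc1)C1Cc2ccccc2C1` gives 21200 nM, the lower of the two actual numbers so far. That is a 4.2-fold lower number from compound 1 to compound 3 (0.62 log units; beyond the scatter), with ethyl in place of hydrogen on an amide-type nitrogen. Compound 2 `O=C(CC(CC(=O)NC1Cc2ccccc2C1)c1ccc(Cl)cc1)NCCN1CCCC1` gives > 100000 nM, which is a limit of the assay and not a number.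

The next comparison is compound 4 `CCN(C(=O)CC(CC(=O)NCCN1CCCC1)c1ccc(Cl)cc1)C1Cc2ccccc2C1`, which differs from compound 3 as follows: pyrrolidin-1-yl in place of piperidin-1-yl on a saturated chain carbon, two bonds along the chain from an amide-type nitrogen. The same exchange has been measured once, on the parent without the ethyl: an at least 1.1-fold higher number from compound 1 to compound 2 (0.05 log units; that floor lies within the scatter). That step is only a floor because of the limit of > 100000 nM in this assay, at which 1 of the 3 values shown sits, so it gives a direction and no true size. Whether the ethyl alters the effect of the exchange has not been measured.

On that single step to compound 2, a modest rise in this assay is expected, and the expected step is a 2.4-fold higher number from compound 3 to compound 4 (0.37 log units; beyond the scatter). A result reported only as a limit remains possible. For compound 4 the estimated value is 50000 nM, with an expected range from 20000 nM to 100000 nM.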

Compound 4, half-maximal inhibitory concentration: 55500 nM
The estimate for compound 4 lay 1.1-fold (0.05 log units) below the measured number; low and high end bracket the measured number.
By their numbers in this assay, from the lowest: compound 3; then compounds 4 and 1 (each within the scatter of the next). At a limit, above all of these: compound 2.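

In this assay the exchange of piperidin-1-yl for pyrrolidin-1-yl now has a true size on the ethyl-bearing core, a 2.6-fold higher number from compound 3 to compound 4 (0.42 log units; beyond the scatter), where the parent pair gave only a direction, and the comparison between the two cores remains incomplete: the same change on two cores in this assay, an at least 1.1-fold higher number (0.05 log units; that floor lies within the scatter) from compound 1 to compound 2 and a 2.6-fold higher number (0.42 log units; beyond the scatter) from compound 3 to compound 4; the limit leaves it open whether they differ The step of ethyl in place of hydrogen on an amide-type nitrogen now has a second reading, an at least 1.8-fold lower number from compound 2 to compound 4 (0.25 log units; that floor lies within the scatter), which runs the same way as the first but is only a floor: the same change on two cores in this assay, a 4.2-fold lower number (0.62 log units; beyond the scatter) from compound 1 to compound 3 and an at least 1.8-fold lower number (0.25 log units; that floor lies within the scatter) from compound 2 to compound 4; the limit leaves it open whether they differ Compound 2 gives > 100000 nM, which is a limit of the assay and not a number.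

The compounds shown do not tell whether morpholin-4-yl, azepan-1-yl or a plain dimethylamino group on the saturated chain carbon, two bonds along the chain from an amide-type nitrogen, would give a lower or a higher number than piperidin-1-yl or pyrrolidin-1-yl. Among the compounds shown here, they also leave open whether propyl or benzyl on the amide-type nitrogen would go lower than compound 3, which gives 21200 nM and has the lowest number so far.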